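Swapping a pyridine for a phenyl in a piperazine amide series

A few compounds are considered here, and "the series" means these few. Any claim that something is new, unique, unknown or untested is made for them only; others in the source may bear on it.

In a functional assay on A549 cells (Homo sapiens) for cytotoxicity, read by MTT assay, with a stated time of 72 h (on this read-out lower numbers stand for stronger inhibition and higher numbers for weaker inhibition), compound 2, whose structure is `O=C(CN1CCN(c2nnc(Cc3ccncc3)c3ccccc23)CC1)Nc1cc(C(F)(F)F)ccc1Cl`, gives 1850 nM. Within the data shown here, this is the only number reported in this assay for the set; compound 1, with structure `O=C(CN1CCN(c2nnc(Cc3ccccc3)c3ccccc23)CC1)Nc1ccc(F)c(Cl)c1`, is recorded in this assay as "not active" (no number reported), with no figure attached. Compound 3, with structure `O=C(CN1CCN(c2nnc(Cc3ccccc3)c3ccccc23)CC1)Nc1cc(C(F)(F)F)ccc1Cl`, has not yet been tested in this assay. It departs from compound 2 by phenyl in place of pyridin-4-yl on a saturated chain carbon bound to an aromatic carbon. Among the measured compounds shown here, no measured pair isolates this change, so its effect is uncertain. Given that compound 1, which also carries the phenyl, gave "not active" (no number reported), a modest loss of potency, at or a little beyond the scatter, is expected from compound 2 to compound 3, a 1.9-fold higher number from compound 2 to compound 3 (0.28 log units; within the scatter). Compound 3 is therefore estimated at 3500 nM in this assay, within a range from 1200 nM to 12000 nM.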

Compound 3, half-maximal inhibitory concentration: 89000 nM
For compound 3 the middle estimate is 25-fold (1.41 log units) below the measured one; the whole stated range lies below it.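

In this assay, among these compounds, this is the first measured look at the position: phenyl in place of pyridin-4-yl gives a 48-fold higher number from compound 2 to compound 3 (1.68 log units; beyond the scatter) on a saturated chain carbon bound to an aromatic carbon. The number thus responds strongly to this swap, even though both groups have the same count of heavy atoms and are each a single six-membered aromatic ring; pyridin-4-yl differs in holding the ring nitrogen, the only hydrogen-bond acceptor of the two. Nothing measured here explains the size of this step.

Going by these compounds, it remains open whether pyridin-3-yl, or a phenyl bearing an amine or a hydroxyl, would give a number closer to that of compound 2. Also open, on these data alone, is whether the change has a similar effect with the different aryl group on the amide of compound 1.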